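This account rests on a few compounds, and the source may have more. Where it says the series, first, only, none or still open, it means among the compounds named here.

Going by the values given here, compound 1 `N#Cc1cnc(NCc2cnccc2C(F)(F)F)cc1NC[C@H]1CC[C@H](O)CC1` gives 2000 nM in an assay on isolated protein for inhibition of protein kinase C delta type (Homo sapiens), read by TR-FRET, with a stated time of 2 h (a higher number here means a weaker inhibitor, a lower number a stronger inhibitor), the highest of the three numbers measured so far. Sharing everything with compound 1 except the group on that nitrogen, compound 3 `CC1(C)C[C@H](Nc2cc(NCc3cnccc3C(F)(F)F)ncc2C#N)CC(C)(C)[C@H]1O` gives 500 nM in this assay, and compound 2 `N#Cc1cnc(NCc2cncnc2OCC(F)F)cc1N[C@H]1CC[C@@H](O)CC1` gives 90 nM. The change from compound 1 to compound 4 `CC1(C)C[C@@H](Nc2cc(NCc3cnccc3C(F)(F)F)ncc2C#N)CC[C@H]1O` is 4-hydroxy-3,3-dimethylcyclohexyl in place of (4-hydroxycyclohexyl)methyl on a nitrogen on an aromatic ring. Since the other two numbers lie well below that of compound 1, with compound 3 at 500 nM and compound 2 at 90 nM, a move downward beyond the scatter is expected, estimated as a 5.0-fold lower number from compound 1 to compound 4 (0.70 log units; beyond the scatter). Compound 4 is therefore expected to give about 400 nM in this assay, within a range of 120 nM to 1300 nM.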

Compound 4, half-maximal inhibitory concentration: 2400 nM
Compound 4: the middle estimate sits 6.0-fold (0.78 log units) below what was measured; the measured number lies above the stated range.
By their numbers in this assay, from the lowest: compound 2; then compound 3; then compounds 1 and 4 (each within the scatter of the next).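

In this assay, 4-hydroxy-3,3-dimethylcyclohexyl in place of (4-hydroxycyclohexyl)methyl gives a 1.2-fold higher number from compound 1 to compound 4 (0.08 log units; within the scatter), so this exchange on the nitrogen does not by itself lower the number. The group on that nitrogen can still matter: compound 4 gives 2400 nM, whereas compound 3, which differs from it only in that group, gives 500 nM. Nothing measured here accounts for either result. Going by these compounds, it remains open whether an amine or a carboxylic acid in place of the hydroxy group would change the number.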